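The compounds below may be only part of what the source reports. "The series", "measured", "known", "first", "only" and "open" are said of these compounds alone.

Measured so far in a functional assay on SGC-7901 cells (Homo sapiens) for antiproliferative activity, read by MTT assay, with a stated time of 24 h; a higher number here means a weaker inhibitor, a lower number a stronger inhibitor:
- compound 1 `Cc1ccccc1NNC(=O)c1ccccc1NS(=O)(=O)c1cnc(O)nc1O`: > 20000 nM (a limit of the assay, not a number)
- compound 2 `CCCCOc1ccc(C(=O)NNC(=O)c2ccccc2NS(=O)(=O)c2cnc(O)nc2O)cc1`: 6890 nM

Going by the values given here, compound 2, at 6890 nM, holds the only numerical value so far. Compound 1 gave only a limit.

Compound 3 `Cc1ccccc1C(=O)NNC(=O)c1ccccc1NS(=O)(=O)c1cnc(O)nc1O` has not yet been measured. It departs from compound 2 in one place, on a carbonyl carbon whose other neighbours are an amide-type nitrogen: 2-methylphenyl in place of 4-butoxyphenyl on a carbonyl carbon. In words, 2-methylphenyl stands in place of 4-butoxyphenyl. Among the compounds with values here, no measured pair differs in a single place, so no direct precedent sets the size of this change in this assay.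

The expected step of a 2.2-fold higher number from compound 2 to compound 3 (0.34 log units; beyond the scatter) is modest and toward weaker inhibition, though this is a low-confidence call. Compound 1 gave only a limit, and that result, (the limit of > 20000 nM in this assay, at which 1 of the 2 values shown sits), is what tilts the expectation toward weaker values. A report of a limit alone would also fit this expectation. For compound 3 the estimated value is 15000 nM, with an expected range of 6000 nM to 35000 nM.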

Compound 3, half-maximal inhibitory concentration: 13000 nM
The estimate for compound 3 lay 1.2-fold (0.06 log units) above the measured number; the range from low to high includes it.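

In this assay, going by these compounds alone, the first single-place comparison on a carbonyl carbon gives a 1.9-fold higher number from compound 2 to compound 3 (0.28 log units; within the scatter): exchanging 4-butoxyphenyl (11 heavy atoms, 1 hydrogen-bond acceptor) for 2-methylphenyl (7 heavy atoms, 0 hydrogen-bond acceptors) leaves the result within the usual scatter, so this change shows no clear effect on antiproliferative activity at this place. The second comparison, on an amine nitrogen, gives an at least 1.5-fold lower number from compound 1 to compound 3 (0.18 log units; that floor lies within the scatter), with (2-methylphenyl)carbonyl in place of 2-methylphenyl; compound 3 gives a number, but the true size of this step cannot be fixed and its floor does not establish a change beyond the scatter. Compound 1 remains a limit of the assay, not a number, and compounds at such a limit still make up part of this small series: the limit of > 20000 nM in this assay, at which 1 of the 3 values shown sits.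

The two groups compared on the carbonyl carbon differ both in their chain and in where it stands on the ring, so the contribution of each feature cannot be separated. As far as these compounds go, whether an unsubstituted phenyl, a longer chain, an amine or a carboxylic acid at this place would move the number beyond the scatter remains open.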